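Second fluoro on the benzyl ring of compound 3

The source may hold more compounds than are shown below. What is called first, only, known or untested is meant among the compounds shown, and "the series" means these compounds.

The measured compounds:
compound 1, `CC(=O)c1ccc(OCc2ccccc2C)cc1`, 42.9%
compound 2, `CC(=O)c1ccc(OCc2ccccc2[N+](=O)[O-])cc1`, 34%
compound 3, `CC(=O)c1ccc(OCc2ccccc2F)cc1`, 47.1%

In an assay on isolated protein for inhibition of Amine oxidase [flavin-containing] A (Homo sapiens), read by Amplex Red, with a stated time of 15 min, tested at 100 uM (a lower number here means less inhibition, a higher number more inhibition at the concentration tested (going by the name of the read-out)), compound 3 gives 47.1%, the highest of the three numbers. Compound 1 stands close, the step of a number 4.2 percentage points higher from compound 1 to compound 3 (within the scatter) lying within the scatter, while the step of a number 13.1 percentage points higher from compound 2 to compound 3 (beyond the scatter) is beyond it. Compound 4, `CC(=O)c1ccc(OCc2ccc(F)cc2F)cc1`, differs from compound 3 in one place: fluoro in place of hydrogen on an aromatic carbon. Going by the values given here, no measured step adds a fluoro in place of hydrogen, so the bearing of the earlier steps is indirect. The nearest is the exchange of methyl for fluoro, a number 4.2 percentage points higher from compound 1 to compound 3 (within the scatter), which stayed within the scatter; the larger move, a number 13.1 percentage points higher from compound 2 to compound 3 (beyond the scatter), involved nitro and is less comparable. The expected step for compound 4 is therefore small, a number 2.9 percentage points higher from compound 3 to compound 4 (within the scatter), not beyond the scatter. In this assay compound 4 is estimated at 50%, with a range from 36% to 64%.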

Compound 4, a percentage reported as inhibition, at one concentration (the size of the read-out at that concentration, not a potency): 45.7%
Compound 4: middle estimate off by 4.3 percentage points, on the high side; the measured number falls inside the stated range.
By their numbers in this assay, from the lowest: compounds 2, 1, 4 and 3 (each within the scatter of the next, the first and the last beyond it).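

In this assay, a fluoro placed on the aromatic carbon para to a large group and meta to a fluoro group gives a number 1.4 percentage points lower from compound 3 to compound 4 (within the scatter), so compound 3 and compound 4 cannot be told apart. The earlier compounds shown here varied a single group on this ring, whereas compound 4 shows that a second group can stand at this position with the read-out still within the scatter of compound 3. No measurement shown explains this result.

As far as these compounds go, it remains open whether a larger group at this position, such as an amine, a carboxylic acid or a methoxy group, would also read like the hydrogen of compound 3 and the fluoro of compound 4. From the compounds shown here alone, it is equally open whether a fluoro at this position would read the same on a ring without the first fluoro.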